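The source may hold more compounds than are shown below. What is called first, only, known or untested is meant among the compounds shown, and "the series" means these compounds.

Compound 1 `COc1ccc(C2C(C#N)=C(N)OC(c3c[nH]c4ccccc34)=C2C#N)cc1OC` gives 19.1%
Compound 2 `N#CC1=C(N)OC(c2c[nH]c3ccccc23)=C(C#N)C1c1cccc2ccccc12` gives 6.8%

Both numbers come from a functional assay, tested at 100 ug/mL; on this read-out lower numbers stand for a weaker effect and higher numbers for a stronger effect at the one concentration tested. Compound 2 stands at the lower of the two values, and its nearest neighbour is compound 1, separated by the step of a number 12.3 percentage points lower from compound 1 to compound 2 (beyond the scatter), a modest shift but one beyond the scatter. That step was the exchange of a 3,4-dimethoxyphenyl for a naphthalen-1-yl on the saturated ring carbon of the shared core.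

Compound 3 `N#CC1=C(N)OC(c2c[nH]c3ccccc23)=C(C#N)C1c1ccccc1` keeps everything of compound 2 except for this change: phenyl in place of naphthalen-1-yl on a saturated ring carbon. Going by the values given here, the one measured step concerned a different group at the same place, so it gives no direct guide to what losing the second aromatic ring of the naphthalen-1-yl will do; it only shows that this position tolerates changes with modest effect. A step of moderate size at most is therefore expected in this assay, and its direction cannot be read from the data, so the estimate leans toward no change beyond the scatter, with the step of a number 3.2 percentage points higher from compound 2 to compound 3 (within the scatter) expected. Compound 3 is estimated at 10%, between 2% and 22%.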

Compound 3, a percentage reported as activity, at one concentration (the size of the read-out at that concentration, not a potency): 19.3%
Compound 3: the middle estimate sits 9.3 percentage points below what was measured, within the range that was stated.
By their numbers in this assay, from the lowest: compound 2; then compounds 1 and 3 (each within the scatter of the next).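

In this assay, replacing naphthalen-1-yl with phenyl on the saturated ring carbon gives a number 12.5 percentage points higher from compound 2 to compound 3 (beyond the scatter), so among these compounds the lower number goes with the group that has the second aromatic ring. The two methoxy groups of the 3,4-dimethoxyphenyl make no readable difference: the change to plain phenyl gives a number 0.2 percentage points higher from compound 1 to compound 3 (within the scatter), which means that, of the three groups at this position, only the naphthalen-1-yl stands apart from the others. No measurement available here explains why this larger group goes with the lower number.

On these data alone, all three compounds carry an aromatic ring of carbon at this position, so what a cyclohexyl group or a longer carbon chain would do in its place remains open. As far as these compounds go, it is also open whether an amine or a carboxylic acid on the phenyl would move the number beyond the range these compounds cover, or whether a second ring fused in another way would behave like the naphthalen-1-yl.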